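The source may report more compounds than this note shows. Statements on the series, on what has been measured and on what is new or still open speak of the compounds shown alone.

Series notes on an ADME assay on stomach for solubility, in simulated gastric fluid; on this read-out higher numbers stand for higher solubility and lower numbers for lower solubility. Of the compounds shown here, three of one shared core have numbers so far. Compound 1 `O=C(Nc1ccc(OC(F)(F)F)cc1)N1CCOC2(CCN(C(=O)c3ccccc3F)CC2)C1` gives 71 ug/mL. Compound 2 `N#Cc1ccc(C(=O)N2CCC3(CC2)CN(C(=O)Nc2ccc(C(F)(F)F)cc2)CCO3)cc1` gives 85 ug/mL. Compound 3 `O=C1Cc2cc(C(=O)N3CCC4(CC3)CN(C(=O)Nc3ccc(OC(F)(F)F)cc3)CCO4)ccc2N1` gives 96 ug/mL. Compound 2 stands second highest of the three, but its gaps to compound 3 and to compound 1 are both within the scatter, so all three read as one level.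

Compound 4 `O=C(CC1CC1)N1CCC2(CC1)CN(C(=O)Nc1ccc(C(F)(F)F)cc1)CCO2` is not yet measured. It differs from compound 2 by cyclopropylmethyl in place of 4-cyanophenyl on a carbonyl carbon.

Among the compounds with values here, the only measured step at the same place, on the carbonyl carbon, is a 1.4-fold higher number from compound 1 to compound 3 (0.13 log units; within the scatter), and it was within the scatter. Within the data shown here, no measured pair covers the exchange of an aromatic group for a cyclopropylmethyl group, so nothing in the data points in either direction. For compound 4 the expectation is therefore a step of a 1.1-fold higher number from compound 2 to compound 4 (0.02 log units; within the scatter) in this assay, none beyond the scatter, resting on the steadiness seen in compound 1 with 71 ug/mL and compound 3 with 96 ug/mL. Compound 4 is estimated at 90 ug/mL, with a range from 45 ug/mL to 180 ug/mL.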

Compound 4, solubility: 79 ug/mL
Estimate against measurement, compound 4: 1.1-fold (0.06 log units) above, within the range that was stated.
By their numbers in this assay, from the lowest: compounds 1, 4, 2 and 3 (each within the scatter of the next).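

In this assay the exchange of 4-cyanophenyl for cyclopropylmethyl on a carbonyl carbon gives a 1.1-fold lower number from compound 2 to compound 4 (0.03 log units; within the scatter) and so shows that this place can carry a group without an aromatic ring and stay at the level of the aromatic examples. Together with a 1.4-fold higher number from compound 1 to compound 3 (0.13 log units; within the scatter) this makes two steps at this place, both within the scatter, and here the six-membered aromatic ring and the nitrile leave together with no readable change. No measurement on hand bears on why the number holds at this place.

Going by these compounds, whether an amine or a carboxylic acid on this carbonyl carbon would take the number beyond the scatter remains open. Every step read so far also sits at this one place, so changes elsewhere on the shared core remain unread.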